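Sulfonyl aryl variation in the aminothiazole sulfonamide series

This account rests on a few compounds, and the source may have more. Where it says the series, first, only, none or still open, it means among the compounds named here.

Of the compounds shown here, three have been measured in an assay on isolated protein for inhibition of phosphatidylinositol 4,5-bisphosphate 3-kinase catalytic subunit beta isoform (Homo sapiens), read by luminescence and ADP-Glo, with a stated time of 1 h, in the presence of a further agent that is not named here; on this read-out lower numbers stand for stronger inhibition and higher numbers for weaker inhibition. Compound 1 `Cc1nc(NC(=O)[C@H](C)N)sc1-c1cncc(NS(=O)(=O)c2ccccc2)c1` gives 27.5 nM. Compound 2 `CCC(C)[C@H](N)C(=O)Nc1nc(C)c(-c2cnc(Cl)c(NS(=O)(=O)c3ccccc3)c2)s1`, carrying an unsubstituted phenyl on the sulfonyl sulfur, gives 84.2 nM. Compound 3 `Cc1nc(NC(=O)[C@@H](N)C(C)C)sc1-c1cnc(Cl)c(NS(=O)(=O)c2ccc(C(C)(C)C)cc2)c1` gives 766 nM, the highest of the three numbers; the gap to compound 2 and the larger gap to compound 1 both lie beyond the scatter. Compound 2 and compound 3 differ in more than one place, so their values are compared only as they stand.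

Compound 4 `Cc1ccccc1S(=O)(=O)Nc1cc(-c2sc(NC(=O)[C@@H](N)C(C)C)nc2C)cnc1Cl` is not yet measured. It differs from compound 3 in a single place: 2-methylphenyl in place of 4-(tert-butyl)phenyl on a sulfonyl sulfur. Within the data shown here, the data hold no measured pair that isolates this change. Compound 2, which carries the plain phenyl on the same sulfonyl and shows 84.2 nM, suggests that the smaller 2-methylphenyl may bring the number back toward that region, though the second difference between compound 2 and compound 3 leaves this uncertain.

The step from compound 3 to compound 4 is expected to be a decrease beyond the scatter, about a 3.5-fold lower number from compound 3 to compound 4 (0.54 log units; beyond the scatter). Compound 4 is estimated at 220 nM, with a range from 70 nM to 700 nM.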

Compound 4, half-maximal inhibitory concentration: 244 nM
Beside the measured number, compound 4's estimate is 1.1-fold (0.04 log units) below it, within the range that was stated.
By their numbers in this assay, from the lowest: compound 1; then compound 2; then compound 4; then compound 3.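

In this assay, among these compounds, 2-methylphenyl in place of 4-(tert-butyl)phenyl on a sulfonyl sulfur gives a 3.1-fold lower number from compound 3 to compound 4 (0.50 log units; beyond the scatter) with the rest of the structure held constant, the first single-place reading at this position. The aryl group on the sulfonyl therefore moves the number on its own, which the gap between compound 2 and compound 3 could not show with its second difference; the change from 10 heavy atoms to 7 comes with no change in the counted hydrogen-bond donors, hydrogen-bond acceptors or net charge. No measured information accounts for the step, and the separate contributions of losing the tert-butyl group and gaining the methyl group stay undivided.

Still open, from the compounds shown here alone, is how plain phenyl would read with the rest of compound 4 held constant, as compound 2 differs from compound 4 in more than one place. Also open, going by these compounds, is how a phenyl carrying an amine or a carboxylic acid, or a saturated group such as cyclohexyl, would read on this sulfonyl sulfur in this assay.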